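This account rests on a few compounds, and the source may have more. Where it says the series, first, only, none or still open, it means among the compounds named here.

Measured compounds:
compound 1 `CCNC(=O)Nc1ccc(/C=C\c2cc(OC)c(OC)c(OC)c2)cc1`: 21000 nM
compound 2 `CCNC(=O)Nc1ccc(/C=C/c2cc(C)cc(C)c2)cc1`: > 20000 nM (a limit of the assay)

Within the data shown here, in a functional assay on M21 cells (Homo sapiens) for inhibition, read by sulforhodamine B assay, with a stated time of 48 h (on this read-out lower numbers stand for stronger inhibition and higher numbers for weaker inhibition), compound 1 gives 21000 nM, the only actual number in hand. Compound 2 reaches only a limit, > 20000 nM. Compound 2 sits at the limit of > 20000 nM in this assay, at which 1 of the 2 values shown sits. Compound 3 `COc1cc(/C=C\c2ccc(N3CCNC3=O)cc2)cc(OC)c1OC` shares the core of compound 1 and differs in one place: 2-oxoimidazolidin-1-yl in place of (ethylcarbamoyl)amino on an aromatic carbon. Among the measured compounds shown here, no measured pair covers this change, so the size of the step rests on expectation alone. The step of a 2.6-fold lower number from compound 1 to compound 3 (0.42 log units; beyond the scatter) is expected to be a modest gain in potency, beyond the scatter but not large. Compound 3 is estimated at 8000 nM, with a range from 1500 nM to 40000 nM.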

Compound 3, half-maximal inhibitory concentration: 2.4 nM
Estimate against measurement, compound 3: 3300-fold (3.52 log units) above; the whole stated range lies above it.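

In this assay 2-oxoimidazolidin-1-yl in place of (ethylcarbamoyl)amino gives an 8800-fold lower number from compound 1 to compound 3 (3.94 log units; beyond the scatter) on an aromatic carbon para to a large group, so this position responds strongly to a change of group. The two groups match in heavy atoms as counted and differ in the five-membered ring and in one hydrogen-bond donor. Nothing at hand accounts for the size of this step.

From the compounds shown here alone, whether the ring or the lost donor carries the step stays open. Also open, going by these compounds, is how a six-membered ring, or a methyl group on the remaining ring nitrogen, would read here.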